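The compounds below may be only part of what the source reports. "The series", "measured", "known", "first", "only" and "open" are said of these compounds alone.

In an ADME assay on microsomes from liver (Mus musculus) for metabolic stability, read by LC-MS, using NADPH, tested at 4.6 uM (on this read-out higher numbers stand for a longer-lived compound and lower numbers for a shorter-lived compound), compound 1 (`O=C(NCCCCc1ccccc1)n1cc(-c2ccccc2)oc1=O`) gives 0.667 h, compound 2 (`O=C(NCCCCc1ccccc1)n1cc(-c2ccc(F)cc2)oc1=O`) gives 1 h and compound 3 (`COc1cccc(-c2cn(C(=O)NCCCCc3ccccc3)c(=O)o2)c1`) gives 0.5 h. Compound 3 thus stands within the scatter of both others, with a 1.3-fold lower number from compound 1 to compound 3 (0.13 log units; within the scatter) and a 2.0-fold lower number from compound 2 to compound 3 (0.30 log units; within the scatter). Compound 4 (`COc1cc(-c2cn(C(=O)NCCCCc3ccccc3)c(=O)o2)ccc1F`) differs from compound 3 by fluoro in place of hydrogen on an aromatic carbon, ortho to a methoxy group. Among the measured compounds shown here, the only measured precedent for this replacement is a 1.5-fold higher number from compound 1 to compound 2 (0.18 log units; within the scatter), which also stays within the scatter. For the measured compounds named here, no measured compound carries both groups, so that precedent is only a rough guide. The expected step is small, a 1.4-fold higher number from compound 3 to compound 4 (0.15 log units; within the scatter), and none beyond the scatter is expected. Compound 4 is estimated at 0.7 h, with a range from 0.4 h to 1.2 h.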

Compound 4, half-life: > 1 h
Compound 4 gave a limit, no number; the forecaster's own chance of this, stated with the estimate: 3%; at least 1.4-fold (0.15 log units) between middle value and limit.
By their numbers in this assay, from the lowest: compounds 3, 1 and 2 (each within the scatter of the next).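

In this assay compound 4 gives > 1 h, which is a limit of the assay and not a number. Fluoro ortho to a methoxy group, the first fluoro shown with that neighbour, gives an at least 2.0-fold higher number from compound 3 to compound 4 (0.30 log units; that floor lies within the scatter), and the larger change gives an at least 1.4-fold higher number from compound 1 to compound 4 (0.17 log units; that floor lies within the scatter), while methoxy in place of hydrogen gives a number no lower from compound 2 to compound 4 (the limit leaves the size open). The fluoro change now stands on two cores: the same change on two cores in this assay, a 1.5-fold higher number (0.18 log units; within the scatter) from compound 1 to compound 2 and an at least 2.0-fold higher number (0.30 log units; that floor lies within the scatter) from compound 3 to compound 4; the limit leaves it open whether they differ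

As far as these compounds go, how far compound 4 lies past its limit remains open. So does whether chloro or a nitrile in place of this fluoro would give a similar half-life.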